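Notes on the step from compound 1 to compound 4

A few compounds are considered here, and "the series" means these few. Any claim that something is new, unique, unknown or untested is made for them only; others in the source may bear on it.

Values in a functional assay on HepG2 cells (Homo sapiens) for inhibition, read by MTT assay, with a stated time of 48 h; on this read-out higher numbers stand for weaker inhibition and lower numbers for stronger inhibition:
compound 1 `COc1cc(/C=N/Nc2nc(-c3ccc(C(F)(F)F)cc3)cs2)c(Br)c(Br)c1OC`: > 100000 nM
compound 2 `COc1cc(/C=N/Nc2nc(-c3cccc(Br)c3)cs2)cc(Br)c1OC`: 66200 nM
compound 3 `COc1ccccc1-c1csc(N/N=C/c2ccc(F)c(F)c2)n1`: > 100000 nM.

Compound 1 gives > 100000 nM, which is a limit of this assay, not a number. Compound 3 gives > 100000 nM, which is likewise a limit. Compound 2 is the only one of the three that returns a number, 66200 nM, and even that sits at the weak end of what this assay resolves. The picture is dominated by the limit of > 100000 nM in this assay, at which 2 of the 3 values shown sit, so there is no measured range within which compound 1 can be placed other than at the limit itself. For the measured compounds named here, no two of the measured compounds differ in a single place, so no measured step is available to calibrate the change below.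

Compound 4 `COc1cc(/C=N/Nc2nc(-c3ccc(Br)cc3)cs2)c(Br)c(Br)c1OC` is not yet measured. It differs from compound 1 by bromo in place of trifluoromethyl on an aromatic carbon; in words, bromo in place of trifluoromethyl on an aromatic carbon. With compound 1 at the limit and compound 2 only just inside the numeric range, the expectation is that the step of an at least 1.1-fold lower number from compound 1 to compound 4 (0.04 log units; that floor lies within the scatter) is no more than the scatter, in either direction. Compound 4 is estimated at 90000 nM, with a range from 30000 nM to 250000 nM, and a limit rather than a number is the more likely report.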

Compound 4, half-maximal inhibitory concentration: > 100000 nM
Compound 4: no number, only a limit; the forecaster's own chance of this, stated with the estimate: 55%; middle value at least 1.1-fold (0.04 log units) away from the limit.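

Compound 1 and compound 4 each return only a limit, not a number, so no step between them can be read: the limit of > 100000 nM in this assay, at which 3 of the 4 values shown sit.

The compounds shown leave open whether bromo in place of trifluoromethyl on an aromatic carbon changes the result at all in this assay.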